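Replacing pyridin-2-yl with allyloxy on the shared core

The source may hold more compounds than are shown below. What is called first, only, known or untested is meant among the compounds shown, and "the series" means these compounds.

In an ADME assay on microsomes from liver (Homo sapiens) for metabolic stability, read by HPLC, using NADPH, with a stated time of 60 min, tested at 1 uM, in the presence of a further agent that is not named here (a lower number here means that the compound disappears faster, a higher number that the compound lasts longer), compound 1 `Cc1cc(-c2ncccn2)cc(C(=O)NNS(=O)(=O)c2ccccc2)c1F` gives 2.72 h, while compound 2 `Cc1cc(-c2ccccn2)cc(C(=O)NNS(=O)(=O)c2ccccc2)c1F` gives 1.08 h, the lowest of the two numbers available. Compound 3 `C=CCOc1cc(C)c(F)c(C(=O)NNS(=O)(=O)c2ccccc2)c1` departs from compound 2 in one place: allyloxy in place of pyridin-2-yl on an aromatic carbon. In short, allyloxy stands in place of pyridin-2-yl on an aromatic carbon, para to a fluoro group.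

Going by the values given here, only one measured step bears on this change. It is a 2.5-fold lower number from compound 1 to compound 2 (0.40 log units; beyond the scatter), a modest step beyond the scatter, made by putting pyridin-2-yl in place of pyrimidin-2-yl. Among the compounds with values here, that step exchanges one aromatic group for another, whereas here the group that enters has no ring, and no measured compound carries allyloxy. It therefore offers a rough scale for the change, but no firm direction. The expectation rests on compound 2 at 1.08 h, with a slight lean towards a lower number and no shift expected beyond the scatter. The estimated step is a 1.2-fold lower number from compound 2 to compound 3 (0.08 log units; within the scatter). For compound 3, the expected half-life is 0.9 h, with an estimated range from 0.35 h to 2.4 h.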

Compound 3, half-life: 0.4 h
Beside the measured number, compound 3's estimate is 2.3-fold (0.35 log units) above it; measured number inside the range.
By their numbers in this assay, from the lowest: compound 3; then compound 2; then compound 1.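

Set on this aromatic carbon, para to a fluoro group, allyloxy gives in this assay a 2.7-fold lower number from compound 2 to compound 3 (0.43 log units; beyond the scatter) and a 6.8-fold lower number from compound 1 to compound 3 (0.83 log units; beyond the scatter), so compound 3 has the lowest number of the three, at 0.4 h. The earlier pair showed only that one aromatic ring could be exchanged for another at this position; this result adds that a group with no ring and a double bond outside aromatic rings moves the half-life further in the same direction, and the step from the pyrimidin-2-yl compound is the largest step shown. Nothing available accounts for these differences, so the result stands as an observation without an established cause.

The compounds shown leave open which feature of allyloxy goes with the lower number: the absence of a ring, the ether oxygen or the double bond. A saturated propoxy chain, a methoxy group or a phenyl ring at the same position would help to separate these features, and an amine there would test a different kind of group on the shared core.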